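This account rests on a few compounds, and the source may have more. Where it says the series, first, only, none or still open, it means among the compounds named here.

Measured compounds:
- compound 1, `Cc1cnc(-c2ccccc2C(C)C)nc1NCc1ccc(-c2cccnc2)cc1`: 70 nM
- compound 2, `CC(C)c1ccccc1-c1nc2c(c(NCc3ccc(-c4cccnc4)cc3)n1)CNC2`: 2900 nM
- compound 3, `Cc1cnc(-c2ccccc2C(C)C)nc1NCc1ccc(-c2ccc(F)nc2)cc1`: 80 nM

In an assay on a protein complex for inhibition of ubiquitin carboxyl-terminal hydrolase 1/WD repeat-containing protein 48 (Homo sapiens), read by fluorescence (a lower number here means a stronger inhibitor, a higher number a weaker inhibitor), compound 3 gives 80 nM, which places it second highest of the three numbers shown: compound 1 sits nearest with 70 nM, and compound 2 lies furthest away with 2900 nM. For the measured compounds named here, the one step that joins compound 3 to another measured compound is a 1.1-fold higher number from compound 1 to compound 3 (0.06 log units; within the scatter), a change that stayed within the scatter.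

Compound 4, `Cc1cnc(-c2ccccc2C(C)C)nc1NCc1ccc(-n2ccnc2)cc1`, is not yet measured. It differs from compound 3 by 1H-imidazol-1-yl in place of 6-fluoropyridin-3-yl on an aromatic carbon of a six-membered aromatic ring of carbon only, para to a large group. Going by the values given here, no measured step touches this position in a comparable way; the step of a 1.1-fold higher number from compound 1 to compound 3 (0.06 log units; within the scatter) only shows that a fluoro on the leaving ring hardly mattered, and compound 2 differs in the core rather than here. The ring that enters is smaller and is a five-membered aromatic ring with two hetero atoms, so some movement is plausible but its direction is unsupported. Compound 4 is therefore expected near compound 3, with a step of a 2.0-fold higher number from compound 3 to compound 4 (0.30 log units; within the scatter) toward a weaker number, and the estimate for compound 4 is 160 nM, in the range 40 nM to 640 nM.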

Compound 4, half-maximal inhibitory concentration: 300 nM
Compound 4: middle estimate off by 1.9-fold (0.27 log units), on the low side; measured number inside the range.
By their numbers in this assay, from the lowest: compounds 1 and 3 (each within the scatter of the next); then compound 4; then compound 2.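

In this assay the ring on the aromatic carbon para to a large group cannot be exchanged without consequence: 1H-imidazol-1-yl in place of 6-fluoropyridin-3-yl gives a 3.8-fold higher number from compound 3 to compound 4 (0.57 log units; beyond the scatter), and the same ring in place of pyridin-3-yl gives a 4.3-fold higher number from compound 1 to compound 4 (0.63 log units; beyond the scatter). Both steps are modest but beyond the scatter, whereas the fluoro on the leaving ring left the number within the scatter, so at this position the identity of the ring counts for more than that fluoro. Nothing available alongside these numbers explains the change.

The entering ring differs from the leaving ring in both ring size and hetero atoms, so the compounds shown cannot separate the two. They also leave open how a plain phenyl ring, a morpholine or a carboxylic acid would fare at this carbon, and whether 1H-imidazol-1-yl would give a similar step on the core of compound 2.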